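A Smaller Aryl Group on the Ring Nitrogen

The compounds below may be only part of what the source reports. "The series", "measured", "known", "first", "only" and "open" are said of these compounds alone.

Measured so far:
compound 1 `CCc1nc(-c2ccccc2F)c(C(=O)N2CCN(c3cccc(Cl)c3)CC2)o1` gives 139 nM
compound 2 `Cc1nc(-c2ccccc2)c(C(=O)N2CCN(c3cccc(Cl)c3Cl)CC2)o1` gives 133 nM
compound 3 `COc1cc(OC)cc(N2CCN(C(=O)c3onc(C)c3-c3ccccc3)CC2)c1` gives 152 nM

All three were tested in a functional assay on HL-60 cells (Homo sapiens) for inhibition, read by MTT assay, with a stated time of 72 h; a higher number here means a weaker inhibitor, a lower number a stronger inhibitor. Compound 2, with its 2,3-dichlorophenyl on the amine nitrogen in the ring, sits together with compound 1 and compound 3: the gaps between the three numbers all lie within the usual scatter, so none of them can be set apart from the others, and compound 2 is simply one of three closely grouped values.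

Compound 4 `Cc1nc(-c2ccccc2)c(C(=O)N2CCN(c3ccccc3)CC2)o1` has not yet been measured. It differs from compound 2 in one place: phenyl in place of 2,3-dichlorophenyl on an amine nitrogen in a ring. Among the measured compounds shown here, no measured pair shows the effect of this change, so nothing on hand says how the two chlorines on that aryl group matter in this assay.

For the measured compounds named here, with no directly comparable pair, the expectation rests on the fact that the three measured compounds, all carrying some substituted aryl group on that ring nitrogen, gave nearly the same number. The step from compound 2 to compound 4 is therefore expected to be modest, with the direction leaning toward a higher number, and it may well stay within the scatter; the expected step is a 2.1-fold higher number from compound 2 to compound 4 (0.32 log units; beyond the scatter). On this basis compound 4 is estimated at 280 nM, with a range from 110 nM to 800 nM.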

Compound 4, half-maximal inhibitory concentration: 39.1 nM
Compound 4: the middle estimate sits 7.2-fold (0.85 log units) above what was measured, outside the stated range (below it).
By their numbers in this assay, from the lowest: compound 4; then compounds 2, 1 and 3 (each within the scatter of the next).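

In this assay, among the compounds shown here, phenyl in place of 2,3-dichlorophenyl on the amine nitrogen in the ring gives a 3.4-fold lower number from compound 2 to compound 4 (0.53 log units; beyond the scatter), a step beyond the scatter and the first reading of this position with the rest of the molecule held the same. The close grouping of the three earlier compounds had hidden this, as they differ from one another in more than one place and so could not isolate the aryl group; the pair of compound 2 and compound 4 shows that the aryl group on this nitrogen does matter in this assay, and that the plain phenyl goes with the lower number on this core. Nothing at hand gives a measured reason for the step.

From the compounds shown here alone, it remains open whether both chlorines are needed for the change or whether a single chlorine on the phenyl would already give a number like that of compound 2, and how a methoxy group, a fluorine or a nitrile on that phenyl would compare. Going by these compounds, it is also open whether the same exchange would move the number in the same direction on the cores of compound 1 and compound 3.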